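The compounds below may be only part of what the source reports. "The series", "measured", "known", "first", "only" and "open" are said of these compounds alone.

Compound 1 `CCC(C)(C)Cc1c[nH]c(CCc2ccc(-n3ncnn3)cc2)n1` sets the starting point: in a functional assay on HEK293 cells for agonist activity at Bombesin receptor subtype-3 (Mus musculus), read by luminescence and calcium flux, with a stated time of 10 min (on this read-out lower numbers stand for an effect already at smaller amounts and higher numbers for an effect only at larger amounts of compound), compound 1 gives 25 nM. Compound 2 `CCC(C)(C)Cc1c[nH]c(CCc2ccc(-c3csnn3)cc2)n1` keeps everything else and carries a different five-membered ring on the six-membered carbon ring; in this assay compound 2 gives 11 nM. That change brought a 2.3-fold lower number from compound 1 to compound 2 (0.36 log units; beyond the scatter). Among the two numbers measured so far, compound 2 therefore stands at the lower end, with compound 1 as its only neighbour.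

Compound 3 `CCC(C)(C)Cc1c[nH]c(CCc2ccc(-c3ccns3)cc2)n1` is the next step from compound 2, again swapping the five-membered ring at the same place: 1,2-thiazol-5-yl in place of 1,2,3-thiadiazol-4-yl on an aromatic carbon. Among the compounds with values here, only one measured step bears on this kind of exchange, the step from compound 1 to compound 2, and it was modest. A swap of one small ring for another of the same size, with one fewer acceptor, gives no strong reason to expect more than a small shift in this assay, in either direction, and the move may well stay within the scatter. The expected step from compound 2 to compound 3 is therefore a 1.5-fold higher number from compound 2 to compound 3 (0.16 log units; within the scatter). Compound 3 is estimated at 16 nM, with a likely range from 5 nM to 50 nM.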

Compound 3, half-maximal effective concentration: 3.1 nM
Compound 3: middle estimate off by 5.2-fold (0.71 log units), on the high side; the whole stated range lies above it.
By their numbers in this assay, from the lowest: compound 3; then compound 2; then compound 1.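

The place on an aromatic carbon of a six-membered aromatic ring of carbon only, para to a large group, still had room for a lower number: in this assay, 1,2-thiazol-5-yl in place of 1,2,3-thiadiazol-4-yl gives a 3.5-fold lower number from compound 2 to compound 3 (0.55 log units; beyond the scatter), even though the two rings are the same size and the entering ring simply has a carbon where the leaving ring has a nitrogen. Measured against the first ring, 1,2-thiazol-5-yl in place of 2H-tetrazol-2-yl gives an 8.1-fold lower number from compound 1 to compound 3 (0.91 log units; beyond the scatter), so the choice of five-membered ring at this one place spans that whole range while the rest of the molecule stays the same. Nothing measured here explains why this ring exchange has such an effect.

On these data alone, all three compounds carry a five-membered aromatic ring at this place, so it remains open how a nitrile, an amide or a six-membered pyridine ring would behave there in this assay. As far as these compounds go, it also remains open whether the same order of rings would hold with a shorter chain in place of the branched chain on the shared core.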